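The compounds below may be only part of what the source reports. "The series", "measured", "known", "first", "only" and "open" are said of these compounds alone.

Series notes: peroxide core with an aryl ether tail.

Compound 1 `N[C@H]1CC[C@H](Oc2ccc([C@H]3CC[C@]4(CC3)OOC3(O4)C4CC5CC(C4)CC3C5)cc2)CC1` carries a 4-aminocyclohexyl on the ether oxygen. In an ADME assay on microsomes from liver (Homo sapiens) for metabolic stability, read by LC-MS, tested at 1 uM (on this read-out higher numbers stand for fast clearance and lower numbers for slow clearance), compound 1 returns only the limit of the assay, < 7 mL.min-1.g-1. Compound 2 `NCCOc1ccc([C@H]2CC[C@]3(CC2)OOC2(O3)C3CC4CC(C3)CC2C4)cc1` carries 2-aminoethyl on that oxygen instead. In this assay compound 2 likewise returns only the limit, < 7 mL.min-1.g-1. The step that the two limits leave unreadable from compound 1 to compound 2 therefore cannot be read as a number; both values sit at the same limit, as summarised in the limit of < 7 mL.min-1.g-1 in this assay, at which 2 of the 2 values shown sit.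

Compound 3 `CC(C)(N)CCOc1ccc([C@H]2CC[C@]3(CC2)OOC2(O3)C3CC4CC(C3)CC2C4)cc1` is the next member and has not been measured in this assay. It differs from compound 2 by 1-amino-1-methylethyl in place of amino on a saturated chain carbon, two bonds along the chain from an oxygen on an aromatic ring.

Bearing on this step there is only the unreadable step that the two limits leave unreadable from compound 1 to compound 2, which shows that both measured members clear slowly, at the limit, and gives no direction. Within the data shown here, no measured step links a saturated-chain change of this kind to a change in clearance, so the expectation rests on the position of compound 2 at the limit, < 7 mL.min-1.g-1. The step from compound 2 to compound 3 is expected to be a number no lower from compound 2 to compound 3 (the limit leaves the size open), within the scatter. For compound 3 in this assay the estimate is 7 mL.min-1.g-1, between 3 mL.min-1.g-1 and 20 mL.min-1.g-1, most likely again reported only as the limit.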

Compound 3, intrinsic clearance in microsomes: < 7 mL.min-1.g-1
Compound 3: only a limit was reported (the forecaster's own chance of this, stated with the estimate: 60%); the middle value sits exactly at the limit.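

In this assay compound 3 returns only a limit, < 7 mL.min-1.g-1. The steps from compound 2 and from compound 1 to compound 3 therefore cannot be read, with all values at one limit: the limit of < 7 mL.min-1.g-1 in this assay, at which 3 of the 3 values shown sit.

Still open, on these data alone, is how far the clearance of compound 1, compound 2 and compound 3 differs, and whether any of these ether-oxygen groups changes it.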